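Swapping the Benzyl Ester for a Small Alkyl Group

The source may hold more compounds than are shown below. What is called first, only, known or untested is meant among the compounds shown, and "the series" means these compounds.

Measured compounds:
compound 1, `COC(=O)c1ccc(COc2ccc(OCCOCCNC3CCCC3)cc2)cc1`: 6990 nM
compound 2, `COC(=O)c1cccc(COc2ccc(OCCOCCNC3CCCC3)cc2)c1`: 45500 nM

In a functional assay on SK-OV-3 cells (Homo sapiens) for inhibition, read by CCK-8 assay, with a stated time of 70 h (on this read-out higher numbers stand for weaker inhibition and lower numbers for stronger inhibition), compound 2 gives 45500 nM, the highest of the two numbers measured, so it is the weaker inhibitor of the pair. Its nearest neighbour is compound 1, and the step of a 6.5-fold higher number from compound 1 to compound 2 (0.81 log units; beyond the scatter) shows that shifting the ester group around the outer ring already cost potency.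

Compound 3, `CCOc1ccc(OCCOCCNC2CCCC2)cc1`, is the next compound to be measured. It differs from compound 2 as follows: methyl in place of 3-(methoxycarbonyl)phenyl on a saturated chain carbon bound to an oxygen on an aromatic ring. Among the measured compounds shown here, the only measured step, a 6.5-fold higher number from compound 1 to compound 2 (0.81 log units; beyond the scatter), concerns the position of the ester on the outer ring and not its removal, so nothing measured speaks directly to the loss of the whole 3-(methoxycarbonyl)phenyl group. Given that compound 2 is already the weakest point and that the outer aromatic ring is dropped altogether, a further rise in the number is expected for compound 3, though with wide uncertainty. Compound 3 is therefore estimated at 70000 nM in this assay, within 20000 nM to 250000 nM, a step of a 1.5-fold higher number from compound 2 to compound 3 (0.19 log units; within the scatter).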

Compound 3, half-maximal inhibitory concentration: 90500 nM
The estimate for compound 3 lay 1.3-fold (0.11 log units) below the measured number; low and high end bracket the measured number.
By their numbers in this assay, from the lowest: compound 1; then compounds 2 and 3 (each within the scatter of the next).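

Putting methyl in place of 3-(methoxycarbonyl)phenyl on a saturated chain carbon bound to an oxygen on an aromatic ring gives a 2.0-fold higher number from compound 2 to compound 3 (0.30 log units; within the scatter) in this assay, so at this place that large group shows no measurable advantage over methyl. Putting methyl in place of 4-(methoxycarbonyl)phenyl instead gives a 13-fold higher number from compound 1 to compound 3 (1.11 log units; beyond the scatter), which shows for the first time that, among these three compounds, only the 4-(methoxycarbonyl)phenyl group stands clearly apart from a small alkyl group, and that compound 1 is the strongest inhibitor of the set. No available evidence accounts for this difference between the two groups.

What remains open is whether the methoxycarbonyl group or the phenyl ring accounts for the stronger inhibition by compound 1, as the compounds shown include neither an unsubstituted phenyl at this place nor a carboxylic acid or an amide in place of the methoxycarbonyl group. They also leave open how a longer chain, such as propyl or butyl, would compare with methyl at this place.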